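Swapping a benzyl for a phenoxy group: what cytotoxicity might follow

The compounds below may be only part of what the source reports. "The series", "measured", "known", "first", "only" and "open" are said of these compounds alone.

Of the compounds shown here, two of a shared core have been tested in an ADME assay on HepG2 cells (Homo sapiens) for cytotoxicity, read by luminescence, CellTiter-Glo and ATP content, with a stated time of 72 h; a higher number here means that more compound is needed for the effect, a lower number that less compound is needed. Compound 1 `COc1cccc(CNCCCNc2ccnc3cc(Cc4ccccc4)ccc23)c1O` gives 5720 nM; compound 2 `COc1ccc(F)cc1CNCCCNc1ccnc2cc(Cc3ccc(F)cc3Cl)ccc12` gives 2460 nM. Compound 1 thus has the higher of the two numbers, and its gap to compound 2 lies beyond the usual scatter, so compound 1 needs more material to reach the same effect on the cells.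

Compound 3 `COc1cccc(CNCCCNc2ccnc3cc(Oc4cccc(N(C)C)c4)ccc23)c1O` has not yet been measured in this assay. It differs from compound 1 in one place: 3-(dimethylamino)phenoxy in place of benzyl on an aromatic carbon. No measured pair in this set shows what such a swap does to the read-out, so the two values given above are the only footing.

With so little to go on, the step from compound 1 to compound 3 in this assay is expected to be small, with a slight lean towards a lower number, as in a 1.4-fold lower number from compound 1 to compound 3 (0.16 log units; within the scatter). Compound 3 is therefore estimated at 4000 nM, with a plausible range from 1500 nM to 12000 nM.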

Compound 3, half-maximal effective concentration: 7300 nM
Estimate against measurement, compound 3: 1.8-fold (0.26 log units) below; the measured number falls inside the stated range.
By their numbers in this assay, from the lowest: compound 2; then compounds 1 and 3 (each within the scatter of the next).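

In this assay, putting 3-(dimethylamino)phenoxy in place of benzyl on this aromatic carbon gives a 1.3-fold higher number from compound 1 to compound 3 (0.11 log units; within the scatter) and so leaves compound 1 and compound 3 indistinguishable in this read-out. The change is not a small one on paper: the entering group has 10 heavy atoms against 7 for benzyl, and 2 hydrogen-bond acceptors against 0, yet this single pair shows no measurable shift in the concentration needed for the effect on the cells. No measurement at hand offers an explanation for this result.

The swap alters the link to the ring and adds the dimethylamino group in a single step, so the compounds shown cannot say what each part does alone; a plain phenoxy group, or a benzyl carrying the same dimethylamino group, would separate the two. They also leave open whether the read-out would stay as it is with a quite different group on this aromatic carbon, such as a carboxylic acid or a morpholine.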